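Replacing vinyl with ethyl in compound 2

The source may report more compounds than this note shows. Statements on the series, on what has been measured and on what is new or still open speak of the compounds shown alone.

Measured so far in a functional assay on RAW264.7 cells (Mus musculus) for inhibition, read by Griess assay, with stated times of 1 h and 24 h; on this read-out lower numbers stand for stronger inhibition and higher numbers for weaker inhibition
Compound 1 `C=CCCCCC/C=C\[C@H](O)C#CC#CC(CC)OC(=O)/C=C/c1ccc(O)cc1` gives 1100 nM
Compound 2 `C=CCCCCC/C=C\[C@@H](C#CC#C[C@@H](O)CC)OC(C)=O` gives 2300 nM

Of these two compounds, compound 2 (2300 nM) has the higher number and so the weaker inhibition. Its gap to compound 1 (1100 nM) lies beyond the usual scatter. The two compounds differ in more than one place, so that gap offers no direct guide to the change considered here.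

Compound 3 `CCCCCCC/C=C\[C@@H](C#CC#C[C@@H](O)CC)OC(C)=O` has not yet been measured. It differs from compound 2 in one place (ethyl in place of vinyl on a saturated chain carbon, five bonds along the chain from a double-bonded chain carbon), with ethyl in place of vinyl on a saturated chain carbon, five bonds along the chain from a double-bonded chain carbon. Among the measured compounds shown here, no measured pair shows this change, so the expectation in this assay is cautious, with no step beyond the scatter and no firm direction. The expected step (a 1.1-fold higher number from compound 2 to compound 3 (0.04 log units; within the scatter)) is accordingly small. The estimated value for compound 3 is 2500 nM (from 1100 nM to 5500 nM).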

Compound 3, half-maximal inhibitory concentration: 32900 nM
For compound 3 the middle estimate is 13-fold (1.12 log units) below the measured one; measured number above the stated range.
By their numbers in this assay, from the lowest: compound 1; then compound 2; then compound 3.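

In this assay, ethyl in place of vinyl on a saturated chain carbon, five bonds along the chain from a double-bonded chain carbon, gives a 14-fold higher number from compound 2 to compound 3 (1.16 log units; beyond the scatter) and so shows that inhibition weakens sharply when this vinyl double bond is saturated, even though the number of heavy atoms in the group stays the same. Compounds 1 and 2 differ in more than one place and could not isolate this position, whereas this pair shows that a change of a single double bond at the chain end is enough to move the read-out far beyond the scatter. Nothing at hand bears on why this double bond matters so much to the read-out.

The compounds shown leave open whether an ethynyl group, or a longer chain that still ends in vinyl, would keep the stronger inhibition of compound 2 at this place. They also leave open whether the same change would weaken inhibition to a similar extent in compound 1, which carries the same vinyl group but a 4-hydroxycinnamate ester in place of the acetate and the free hydroxyl arrangement of compound 2.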